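This account rests on a few compounds, and the source may have more. Where it says the series, first, only, none or still open, it means among the compounds named here.

Measured so far:
Compound 1, `COc1ccccc1/C(=C\c1cn(C(C)=O)c2ccc(OCc3ccccc3)cc12)C(=O)O`: 1010 nM
Compound 2, `CC(=O)n1cc(/C=C(/C(=O)O)c2ccc(Cl)cc2)c2cc(OCc3ccccc3)ccc21`: 1130 nM

Both values come from a functional assay on DU-145 cells (Homo sapiens) for cytotoxicity, read by MTT assay, with a stated time of 72 h; on this read-out higher numbers stand for weaker inhibition and lower numbers for stronger inhibition. Of the two numbers, compound 2 nominally holds the higher one, but its gap to compound 1, the nearest value, lies within the scatter, so the two cannot be told apart. Compound 3, `COc1ccc(OC)c(/C(=C\c2cn(C(C)=O)c3ccc(OCc4ccccc4)cc23)C(=O)O)c1`, has not yet been measured. It differs from compound 2 in one place: 2,5-dimethoxyphenyl in place of 4-chlorophenyl on a double-bonded chain carbon bound to a carbonyl carbon and a double-bonded chain carbon. For the measured compounds named here, the only measured step that bears on this, an exchange of one aryl group for another at the same place, is a 1.1-fold higher number from compound 1 to compound 2 (0.05 log units; within the scatter), which stayed within the scatter. On that basis compound 3 is expected to show a step of a 1.1-fold lower number from compound 2 to compound 3 (0.05 log units; within the scatter), meaning no change beyond the scatter in this assay. The estimate for compound 3 in this assay is therefore 1000 nM, with a range from 400 nM to 2500 nM.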

Compound 3, half-maximal inhibitory concentration: 830 nM
Compound 3: middle estimate off by 1.2-fold (0.08 log units), on the high side; measured number inside the range.
By their numbers in this assay, from the lowest: compounds 3, 1 and 2 (each within the scatter of the next).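

In this assay, a third aryl group at this place, on a double-bonded chain carbon bound to a carbonyl carbon and a double-bonded chain carbon, again gives no readable change: the exchange of 4-chlorophenyl for 2,5-dimethoxyphenyl is a 1.4-fold lower number from compound 2 to compound 3 (0.13 log units; within the scatter) and brings in 10 heavy atoms for 7 and 2 hydrogen-bond acceptors for 0. The result also adds a smaller comparison, since methoxy in place of hydrogen on an aromatic carbon is a 1.2-fold lower number from compound 1 to compound 3 (0.09 log units; within the scatter) and so does not separate these two compounds either. No measurement at hand accounts for how closely these numbers sit.

On these data alone, all three compounds carry a substituted phenyl ring here, so the effect of a methyl group or a plain hydrogen at this place remains open. So does that of a phenyl ring bearing an amine.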